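Swapping a pyridine for an isothiazole on the shared core

This account rests on a few compounds, and the source may have more. Where it says the series, first, only, none or still open, it means among the compounds named here.

Of the compounds shown here, three sharing one core have been measured in an in vitro assay on CHO cells for displacement of a labelled ligand from Bombesin receptor subtype-3 (Homo sapiens), read by scintillation counting, with a stated time of 2 h; on this read-out higher numbers stand for weaker inhibition and lower numbers for stronger inhibition. Compound 1 `CCC(C)(C)Cc1c[nH]c(CCc2ccc(-n3ncnn3)cc2)n1` gives 205 nM. Compound 2 `CCC(C)(C)Cc1c[nH]c(CCc2ccc(-c3cccc(N)n3)cc2)n1` gives 7.3 nM, and compound 3 `CCC(C)(C)Cc1c[nH]c(CCc2ccc(-c3cccnc3)cc2)n1` gives 7.5 nM. Among these three numbers compound 3 stands second highest, yet its gap to compound 2 is within the scatter, as the step of a 1.0-fold higher number from compound 2 to compound 3 (0.01 log units; within the scatter) shows, while the step of a 27-fold lower number from compound 1 to compound 3 (1.44 log units; beyond the scatter) lies well beyond it. In other words, compound 2 and compound 3 cannot be told apart, and both are far stronger than compound 1.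

Compound 4 `CCC(C)(C)Cc1c[nH]c(CCc2ccc(-c3ccns3)cc2)n1` has not yet been measured. It differs from compound 3 in one place: 1,2-thiazol-5-yl in place of pyridin-3-yl on an aromatic carbon. Of the measured steps, only a 27-fold lower number from compound 1 to compound 3 (1.44 log units; beyond the scatter) and a 28-fold lower number from compound 1 to compound 2 (1.45 log units; beyond the scatter) concern a five-membered ring at this position, and there the five-membered ring was the much weaker partner. Going by the values given here, the new ring, however, carries fewer hetero atoms than the one in compound 1, so a weakening of that size is not taken for granted. A moderate rise in the number is expected for compound 4, as a 2.7-fold higher number from compound 3 to compound 4 (0.43 log units; beyond the scatter). Compound 4 is therefore estimated at 20 nM, within a range of 5 nM to 80 nM.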

Compound 4, half-maximal inhibitory concentration: 11 nM
Estimate against measurement, compound 4: 1.8-fold (0.26 log units) above, and the stated range covers the measured number.
By their numbers in this assay, from the lowest: compounds 2, 3 and 4 (each within the scatter of the next); then compound 1.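

In this assay, the aromatic carbon para to a large group accepts a five-membered aromatic ring as readily as a six-membered one: 1,2-thiazol-5-yl in place of pyridin-3-yl gives a 1.5-fold higher number from compound 3 to compound 4 (0.17 log units; within the scatter) and, in place of 6-aminopyridin-2-yl, a 1.5-fold higher number from compound 2 to compound 4 (0.18 log units; within the scatter) as well. Compound 1 also carries a five-membered aromatic ring here, yet 1,2-thiazol-5-yl in place of its 2H-tetrazol-2-yl gives a 19-fold lower number from compound 1 to compound 4 (1.27 log units; beyond the scatter) and is a large step, so among these compounds ring size alone does not account for the weak number of compound 1; which ring is attached matters, not merely how many atoms it holds. Nothing measured here explains why these two five-membered rings differ so widely.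

As far as these compounds go, it remains open whether a plain phenyl ring, made of carbon only, or a thiophen-2-yl ring, with sulfur and no nitrogen, would stay level with compounds 2, 3 and 4 at this place. Also open, from the compounds shown here alone, is how a non-aromatic morpholine ring or a carboxylic acid would fare on the same carbon.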